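The source may report more compounds than this note shows. Statements on the series, on what has been measured and on what is new or still open speak of the compounds shown alone.

Three compounds have been measured in a functional assay on HCT-116 cells (Homo sapiens) for inhibition, read by sulforhodamine B assay, with a stated time of 48 h, tested at 50 uM; a lower number here means less inhibition of growth, a higher number more inhibition of growth at the concentration tested:

Compound 1 `COc1ccccc1/C=C/C(=O)/C=C/c1ccc(OCc2cn(CCOc3cc(=O)oc4ccccc34)nn2)c(OC)c1`: 70%
Compound 2 `COc1ccc(/C=C/C(=O)/C=C/c2ccc(OCc3cn(CCOc4cc(=O)oc5ccccc45)nn3)c(OC)c2)cc1OC`: 82%
Compound 3 `COc1cccc(/C=C/C(=O)/C=C/c2ccc(OCc3cn(CCOc4cc(=O)oc5ccccc45)nn3)c(OC)c2)c1`: 70%

Compound 3 stands level with compound 1 at the digits printed, and the two together are the lowest of the three numbers; the only gap beyond the scatter is a number 12 percentage points lower from compound 2 to compound 3 (beyond the scatter). Compound 4 `COc1cc(/C=C/C(=O)/C=C/c2cccs2)ccc1OCc1cn(CCOc2cc(=O)oc3ccccc23)nn1` differs from compound 3 in one place: thiophen-2-yl in place of 3-methoxyphenyl on a double-bonded chain carbon bound to a double-bonded chain carbon. The measured steps all swap one aryl group for another at this same place, and they were small: a number 12 percentage points higher from compound 1 to compound 2 (beyond the scatter), no change at the digits printed from compound 1 to compound 3 (within the scatter), a number 12 percentage points lower from compound 2 to compound 3 (beyond the scatter). None of them brings in a thiophen-2-yl, so the expected step is a number 4 percentage points lower from compound 3 to compound 4 (within the scatter), no more than the scatter. Compound 4 is therefore estimated at 66%, between 46% and 84%.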

Compound 4, percent growth inhibition at one concentration: 71%
For compound 4 the middle estimate is 5 percentage points below the measured one; measured number inside the range.
By their numbers in this assay, from the lowest: compounds 1, 3 and 4 (each within the scatter of the next); then compound 2.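

In this assay, the five-membered sulfur ring of thiophen-2-yl can stand at this place without loss against either single-methoxy ring (a number 1 percentage points higher from compound 3 to compound 4 (within the scatter); a number 1 percentage points higher from compound 1 to compound 4 (within the scatter)), so a methoxyphenyl group is not required for this level of growth inhibition. Against 3,4-dimethoxyphenyl, the change costs a modest amount (a number 11 percentage points lower from compound 2 to compound 4 (beyond the scatter)), leaving compound 2 clearly above the other three. Nothing available here explains these numbers.

Going by these compounds, what a furan-2-yl ring, a pyridin-2-yl ring or a phenyl ring bearing a carboxylic acid would do at this place remains open. Readings at one concentration also leave open how growth inhibition changes with dose.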